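The compounds below may be only part of what the source reports. "The series", "measured", "known", "first", "only" and "open" are said of these compounds alone.

Measured compounds:

Compound 1, `O=C1C(=O)N(Cc2ccc(-c3ccccc3)nc2)c2ccc(OC(F)(F)F)cc21`: 3800 nM
Compound 2, `O=C1C(=O)N(Cc2ccc(-c3ccncc3)nc2)c2ccc(OC(F)(F)F)cc21`: 4400 nM
Compound 3, `O=C1C(=O)N(Cc2ccc(-c3ccccc3)cc2)c2ccc(OC(F)(F)F)cc21`: 1600 nM

The three measured compounds were tested in a functional assay on CHO cells for positive allosteric modulation of muscarinic acetylcholine receptor M5 (Homo sapiens), read by FLIPR and calcium flux, with a stated time of 1 h; on this read-out higher numbers stand for an effect only at larger amounts of compound and lower numbers for an effect already at smaller amounts. Compound 1 gives 3800 nM in this assay, and compound 2 gives 4400 nM. The change between them is pyridin-4-yl in place of phenyl on an aromatic carbon, and it produced a 1.2-fold higher number from compound 1 to compound 2 (0.06 log units; within the scatter). Compound 3 gives 1600 nM in this assay, the lowest of the three numbers; the difference between the core of compound 1 and the core of compound 3 is not broken down here.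

Compound 4, `O=C1C(=O)N(Cc2ccc(-c3ccncc3)cc2)c2ccc(OC(F)(F)F)cc21`, has not yet been measured in this assay. It differs from compound 3 by pyridin-4-yl in place of phenyl on an aromatic carbon. Going by the values given here, this is the same kind of change as the one from compound 1 to compound 2, but not the same: there the incoming group sat on an aromatic carbon of a six-membered aromatic ring with 1 nitrogen, next to the ring nitrogen, para to a large group, whereas in compound 4 it sits on an aromatic carbon of a six-membered aromatic ring of carbon only, para to a large group.

Since the earlier step was within the scatter, compound 4 is expected to sit close to compound 3, with an estimated step of a 1.2-fold higher number from compound 3 to compound 4 (0.07 log units; within the scatter), resting on a 1.2-fold higher number from compound 1 to compound 2 (0.06 log units; within the scatter). The estimate for compound 4 in this assay is 1900 nM, expected to fall between 1000 nM and 4000 nM.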

Compound 4, half-maximal effective concentration: 2800 nM
The estimate for compound 4 lay 1.5-fold (0.17 log units) below the measured number; the range from low to high includes it.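

In this assay, putting pyridin-4-yl in place of phenyl on the carbon-only ring gave a 1.8-fold higher number from compound 3 to compound 4 (0.24 log units; within the scatter), so on this core too the exchange leaves the number within the usual scatter. Set beside the earlier step on the core with a ring nitrogen, the two results cannot be told apart, and the change carries over from one core to the other without a detectable difference: the same change on two cores in this assay, a 1.2-fold higher number (0.06 log units; within the scatter) from compound 1 to compound 2 and a 1.8-fold higher number (0.24 log units; within the scatter) from compound 3 to compound 4, 1.5-fold (0.18 log units) apart, within the scatter of two such steps. Going by these compounds alone, this shows only that the exchange made no measurable difference on these two closely related cores; it gives no direction for the step, does not show that the two steps are truly equal, and says nothing about how the change would behave on any other core.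

The compounds shown leave open whether a group of a different kind in place of the pyridin-4-yl, such as an amine, a carboxylic acid or a longer alkyl chain, would stay within the scatter in this assay as well. They also leave open what would follow if the trifluoromethoxy group shared by all four compounds were replaced, for instance by methoxy or a simple chlorine atom.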